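Aromatic nitrogen substituent change and effective dose in rats

This account rests on a few compounds, and the source may have more. Where it says the series, first, only, none or still open, it means among the compounds named here.

Of the compounds shown here, two have been measured. Compound 1 `CC(/N=C(/NC#N)Nc1cccnc1)C(C)(C)C` and compound 2 `CCC(C)(C)N/C(=N\C#N)Nc1ccc[n+]([O-])c1` were run in a functional assay on the whole organism (blood, strain Wistar-Okamoto) with Rattus norvegicus as the target, with a stated time of 5 days; a higher number here means that more compound is needed for the effect, a lower number that less compound is needed. In this assay compound 1 gives 1 mg/kg, and compound 2 gives 20 mg/kg. Compound 2 therefore stands at the higher of the two numbers; compound 1 sits at a lower number, and the gap between them lies beyond the usual scatter. The two compounds differ in more than one place, so no single step can be read from this pair.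

Compound 3 `CCC(C)(C)N/C(=N\C#N)Nc1ccc[n+](C)c1` is the next member and differs from compound 2 at one place only: one carbon atom in place of one oxygen atom, on an aromatic nitrogen. Going by the values given here, no measured pair shows what a change on the aromatic nitrogen does to the read-out, so the expected step is uncertain; the working expectation is a step from compound 2 to compound 3 of roughly a 1.5-fold higher number from compound 2 to compound 3 (0.18 log units; within the scatter), at most modestly towards a higher number and possibly none beyond the scatter. On this basis compound 3 is estimated at 30 mg/kg in this assay, with a range from 5 mg/kg to 150 mg/kg.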

Compound 3, minimum effective dose: 20 mg/kg
Compound 3: the middle estimate sits 1.5-fold (0.18 log units) above what was measured; measured number inside the range.
By their numbers in this assay, from the lowest: compound 1; then compounds 2 and 3 (each within the scatter of the next).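

The exchange on this aromatic nitrogen can now be read on its own, which the pair of compound 1 and compound 2 did not allow: in this assay methyl in place of the oxygen gives no change at the digits printed from compound 2 to compound 3 (within the scatter) and leaves the two compounds side by side in the series. The read-out does not separate the two substituents in this pair, although the oxygen that leaves counts a net charge of -1 and a hydrogen-bond acceptor and the methyl that enters counts neither. No measurement shown here bears on why these two substituents read alike.

From the compounds shown here alone, what an ethyl group, a longer chain or a benzyl group on the same aromatic nitrogen would give remains open, as does the reading of this side chain with nothing on that nitrogen. Going by these compounds alone, the lower number of compound 1 stays unassigned, since compound 1 differs from compound 2 and from compound 3 in more than one place and no single step links it to either.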